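The source may hold more compounds than are shown below. What is called first, only, known or untested is meant among the compounds shown, and "the series" means these compounds.

Measured compounds:
compound 1, `COc1cc(-c2nc(CO[C@@H]3O[C@H](CSc4ncn[nH]4)[C@H]4OC5(CCCC5)O[C@@H]34)no2)cc(OC)c1OC`, in a functional assay on WiDr cells (Homo sapiens) for antiproliferative activity, read by sulforhodamine B assay, with a stated time of 48 h; on this read-out higher numbers stand for weaker inhibition of growth and lower numbers for stronger inhibition of growth: 42000 nM
compound 2, `Nc1nnc(SC[C@H]2O[C@@H](OCc3noc(-c4ccc([N+](=O)[O-])cc4)n3)[C@@H]3OC4(CCCC4)O[C@@H]32)s1`, in this assay: 26000 nM
compound 3, `COc1cc(-c2nc(CO[C@@H]3O[C@H](CSc4nnc(N)s4)[C@H]4OC5(CCCC5)O[C@@H]34)no2)cc(OC)c1OC`, in this assay: 41000 nM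

Compound 1 carries the highest of the three numbers, but none of the three stands apart: the step of a 1.0-fold lower number from compound 1 to compound 3 (0.01 log units; within the scatter) is within the scatter, and the values of compound 1 and compound 2 are likewise within the scatter of each other. Going by the values given here, the series so far shows no change that moves the read-out beyond noise.

Compound 4, `Clc1ccc(-c2nc(CO[C@@H]3O[C@H](CSc4ncn[nH]4)[C@H]4OC5(CCCC5)O[C@@H]34)no2)cc1`, is not yet measured. Against compound 1 the change is 4-chlorophenyl in place of 3,4,5-trimethoxyphenyl on an aromatic carbon. Among the compounds with values here, the one measured step that bears on it is the swap of the aryl group at the same position, a 1.6-fold higher number from compound 2 to compound 3 (0.20 log units; within the scatter), which stayed within the scatter. The other step, a 1.0-fold lower number from compound 1 to compound 3 (0.01 log units; within the scatter), concerns the group on the sulfur and does not speak to an aryl exchange; it too was within the scatter. Within the data shown here, with only that one relevant step, and it flat, no movement beyond the scatter is expected for compound 4, so the expected step is a 1.2-fold lower number from compound 1 to compound 4 (0.08 log units; within the scatter). The estimate for compound 4 in this assay is 35000 nM, expected to fall between 12000 nM and 100000 nM.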

Compound 4, concentration for 50% growth inhibition: 4500 nM
The estimate for compound 4 lay 7.8-fold (0.89 log units) above the measured number; measured number outside the range, below it.
By their numbers in this assay, from the lowest: compound 4; then compounds 2, 3 and 1 (each within the scatter of the next).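

In this assay, the aryl group on the five-membered aromatic ring with 2 nitrogen and 1 oxygen proves able to move the read-out, since the change to 4-chlorophenyl gives a 9.3-fold lower number from compound 1 to compound 4 (0.97 log units; beyond the scatter) with 1H-1,2,4-triazol-5-yl on the sulfur. Going by these compounds alone, the only earlier aryl exchange, a 1.6-fold higher number from compound 2 to compound 3 (0.20 log units; within the scatter) with 5-amino-1,3,4-thiadiazol-2-yl on the sulfur, stayed flat, so this position is not insensitive in general, though that exchange involved a different pair of aryl groups and the two results cannot be set directly against each other. The change to compound 4 also swaps a larger group carrying oxygen for a smaller one carrying chlorine, and the step alone cannot separate the loss of the methoxy groups from the gain of the chlorine, while no measurement shown speaks to the reason for the step.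

The compounds shown leave open whether plain phenyl, 4-fluorophenyl or 4-methoxyphenyl would keep the number of compound 4, which would show whether the chlorine itself matters. They also leave open whether 4-chlorophenyl gives a similar step with 5-amino-1,3,4-thiadiazol-2-yl on the sulfur.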